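Five fluorines in place of two on the phenoxy group

The source may hold more compounds than are shown below. What is called first, only, known or untested is meant among the compounds shown, and "the series" means these compounds.

Compound 1, `CC(C)[C@H](NC(=O)COc1cccc2ccccc12)C(=O)N[C@@H](CC(=O)O)C(=O)COc1ccccc1C(F)(F)F`: > 100000 nM
Compound 2, `CC(C)[C@H](NC(=O)COc1cccc2ccccc12)C(=O)N[C@@H](CC(=O)O)C(=O)COc1ccc(C#N)cc1`: > 100000 nM
Compound 3, `CC(C)[C@H](NC(=O)COc1cccc2ccccc12)C(=O)N[C@@H](CC(=O)O)C(=O)COc1cc(F)ccc1F`: > 100000 nM

All three measured compounds share one core and differ only in the phenoxy group at the end of the chain. In a functional assay on Jurkat cells (Homo sapiens) (a higher number here means a weaker inhibitor, a lower number a stronger inhibitor), compound 3 stands at a limit of the assay rather than at a measured number. The same holds across the set: the limit of > 100000 nM in this assay, at which 3 of the 3 values shown sit. Every value is a limit. The steps a step that the two limits leave unreadable from compound 1 to compound 2, a step that the two limits leave unreadable from compound 1 to compound 3 and a step that the two limits leave unreadable from compound 2 to compound 3 cannot be read, and none of them shows whether changing this phenoxy group moves the number at all.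

Compound 4, `CC(C)[C@H](NC(=O)COc1cccc2ccccc12)C(=O)N[C@@H](CC(=O)O)C(=O)COc1c(F)c(F)c(F)c(F)c1F`, differs from compound 3 in one place: 2,3,4,5,6-pentafluorophenyl in place of 2,5-difluorophenyl on an oxygen on a saturated carbon. Within the data shown here, no measured step bears on this change in a readable way, and all three phenoxy variants sit at the limit. Compound 4 is therefore expected to sit at the limit as well, with an estimate of 100000 nM, between 30000 nM and 300000 nM. The expected step of a number no higher from compound 3 to compound 4 (the limit leaves the size open) is meant as no change beyond the scatter.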

Compound 4, half-maximal inhibitory concentration: 3050 nM
Estimate against measurement, compound 4: 33-fold (1.52 log units) above, outside the stated range (below it).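

In this assay, the phenoxy group now proves able to move the number: 2,3,4,5,6-pentafluorophenyl in place of 2,5-difluorophenyl gives an at least 32-fold lower number from compound 3 to compound 4 (1.51 log units; beyond the scatter). The other two phenoxy groups lead to the same picture, with an at least 32-fold lower number from compound 2 to compound 4 (1.51 log units; beyond the scatter) and an at least 32-fold lower number from compound 1 to compound 4 (1.51 log units; beyond the scatter). Compound 4 alone has a measured number, so each step gives only a minimum size, and the other three compounds remain at a limit: the limit of > 100000 nM in this assay, at which 3 of the 4 values shown sit.

The steps among compound 1, compound 2 and compound 3 still cannot be read, and the compounds shown do not separate the count of fluorines from their places, as no tetrafluorophenyl group stands among them. They also leave open whether the fluorines themselves are needed, which a pentachlorophenyl group on the same oxygen could test.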